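Chloro in place of methyl on a shared core

The compounds below may be only part of what the source reports. "The series", "measured", "known", "first", "only" and "open" are said of these compounds alone.

Compound 3 `Cc1ccc2oc(CSc3nnc(C)s3)cc(=O)c2c1` carries a methyl on an aromatic carbon of the shared core. In a functional assay on HeLa cells (Homo sapiens) for cytotoxicity, read by MTT assay, with a stated time of 72 h (on this read-out higher numbers stand for weaker inhibition and lower numbers for stronger inhibition), compound 3 gives > 25000 nM, which is a limit of the assay and not a number. Compound 1 `Cc1nnc(SCc2cc(=O)c3ccccc3o2)s1` has hydrogen where compound 3 has methyl; in this assay compound 1 gives > 25000 nM, again a limit. Compound 2 `Nc1nnc(SCc2cc(=O)c3cc(Cl)ccc3o2)s1` carries a chloro together with an amino group on its thiadiazole; in this assay compound 2 gives > 25000 nM, once more a limit. The only step among these, a step that the two limits leave unreadable from compound 1 to compound 3, therefore cannot be sized, and the limit of > 25000 nM in this assay, at which 3 of the 3 values shown sit, means that no difference between any two of them can be read.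

Compound 4 `Cc1nnc(SCc2cc(=O)c3cc(Cl)ccc3o2)s1` differs from compound 3 by chloro in place of methyl on an aromatic carbon. Within the data shown here, no measured step bears on this exchange in readable form; the closest analogue with a chloro, compound 2, sits at the same limit as the others. For compound 4 the expected step is a number no higher from compound 3 to compound 4 (the limit leaves the size open), that is, none that the assay could show. Compound 4 is accordingly expected to give about 25000 nM in this assay, within a range from 8000 nM to 25000 nM, most likely reported again only as a limit.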

Compound 4, half-maximal inhibitory concentration: > 25000 nM
Compound 4 ended at the assay's limit (the forecaster's own chance of this, stated with the estimate: 85%); the middle value lies on the limit itself.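

Among these compounds, no step from compound 1, compound 2 or compound 3 to compound 4 can be read, because all four compounds share one limit and not a number: the limit of > 25000 nM in this assay, at which 4 of the 4 values shown sit.

The compounds shown leave open whether methyl, chloro, hydrogen or amino makes any difference in this assay, and what number any of these four compounds would give.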